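Extending the anilide of compound 2 with a 3-cyanophenyl group

The source may hold more compounds than are shown below. What is called first, only, known or untested is meant among the compounds shown, and "the series" means these compounds.

Compound 2 `O=C(CCc1cccc2c1B(O)OC2)Nc1ccccc1` gives 350 nM in a functional assay on HCT-116 cells (Homo sapiens) for antiproliferative activity, read by MTT assay, with a stated time of 72 h (a higher number here means a weaker inhibitor, a lower number a stronger inhibitor), the lowest of the two numbers at hand. Compound 1 `CC(C)(C)NC(=O)CCc1cccc2c1B(O)OC2` gives only a limit, > 100000 nM, in this assay. Compound 3 `C#Cc1ccccc1NC(=O)CCc1cccc2c1B(O)OC2` gives 1400 nM in this assay. The step of an at least 280-fold lower number from compound 1 to compound 2 (2.45 log units; beyond the scatter) was large, whereas a 4.0-fold higher number from compound 2 to compound 3 (0.60 log units; beyond the scatter) was modest. Compound 4 `N#Cc1cccc(-c2cccc(NC(=O)CCc3cccc4c3B(O)OC4)c2)c1` differs from compound 2 by 3-cyanophenyl in place of hydrogen on an aromatic carbon, sitting meta to a large group. Within the data shown here, the only step that bears on it is the one from compound 2 to compound 3, where an ethynyl in place of hydrogen on an aromatic carbon raised the number modestly. A modest rise is therefore expected for compound 4, at 900 nM within 200 nM to 4000 nM in this assay. That corresponds to an expected 2.6-fold higher number from compound 2 to compound 4 (0.41 log units; beyond the scatter).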

Compound 4, half-maximal inhibitory concentration: 140 nM
Compound 4: the middle estimate sits 6.4-fold (0.81 log units) above what was measured; measured number outside the range, below it.
By their numbers in this assay, from the lowest: compound 4; then compound 2; then compound 3. At a limit, above all of these: compound 1.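

On this aromatic carbon, a large group did not cost activity in this assay: 3-cyanophenyl in place of hydrogen gave a 2.5-fold lower number from compound 2 to compound 4 (0.40 log units; beyond the scatter). Substitution on the aromatic ring of compound 2 therefore does not always raise the number, as the ethynyl step alone had suggested with a 4.0-fold higher number from compound 2 to compound 3 (0.60 log units; beyond the scatter). Nothing in the data at hand explains this gain. The compounds shown leave open whether the added ring or its nitrile carries the change. A plain phenyl, or an aminophenyl, on the same carbon would separate the two.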